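The compounds below may be only part of what the source reports. "The series", "measured", "known", "first", "only" and "open" are said of these compounds alone.

Measured compounds:
- compound 1, `O=C1c2ccc(O)c(O)c2C(=O)N1Cc1ccc(F)cc1`: "not determined" (no result reported) in an ADME assay on HOS cells (Homo sapiens) for cytotoxicity; a higher number here means a weaker inhibitor, a lower number a stronger inhibitor
- compound 2, `O=C1c2c(ccc(O)c2O)CN1Cc1cccc(F)c1`: 8600 nM
- compound 3, `O=C1c2c(ccc(O)c2O)CN1Cc1ccc(F)c(F)c1`: 9010 nM

Compound 2 and compound 3 share one core and differ by a single change, (fluoro in place of hydrogen on an aromatic carbon). That change gives a 1.0-fold higher number from compound 2 to compound 3 (0.02 log units; within the scatter), so the two values show no separation in this assay. Compound 1 has a different core; the difference between the two cores is not broken down here, and compound 1 has no number of its own in this assay.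

Compound 4, `O=C1c2ccc(O)c(O)c2C(=O)N1Cc1ccc(F)c(F)c1`, arises from compound 1 by the same kind of change, (fluoro in place of hydrogen on an aromatic carbon). The surroundings of the place differ: in compound 3 the entering fluoro is para to a large group, in compound 4 it is meta to a large group.

Among the measured compounds shown here, for this assay, compound 4 is expected to land close to the values of compound 2 and compound 3, since the one measured fluoro step, a 1.0-fold higher number from compound 2 to compound 3 (0.02 log units; within the scatter), is within the scatter. Compound 4 is therefore estimated at 9000 nM, between 3000 nM and 30000 nM, with the wider range owing to the unmeasured core of compound 1.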

Compound 4, half-maximal inhibitory concentration: 7940 nM
The estimate for compound 4 lay 1.1-fold (0.05 log units) above the measured number; low and high end bracket the measured number.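

In this assay, among the compounds shown here, compound 1 stands as "not determined" (no result reported) while compound 4 gives 7940 nM, and no step between the two can be read. The compounds shown leave open what the fluoro does on the core of compound 1, and how the two cores compare in this assay. Nothing at hand bears on a cause for these values.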